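The compounds below may be only part of what the source reports. "The series", "measured", "known", "first", "only" and "open" are said of these compounds alone.

Compound 1 `Cc1cc(C(=O)O)nn1Cc1cc(Br)ccc1OCc1ccccc1` gives 6.46 nM in an assay on CHO-K1 cells for displacement of a labelled ligand from prostaglandin E2 receptor EP1 subtype (Homo sapiens); a higher number here means a weaker inhibitor, a lower number a stronger inhibitor.
Compound 2 `Cc1cc(C(=O)O)nn1Cc1cc(Br)ccc1OCc1ccc(Cl)cc1Cl` gives 0.132 nM in this assay.
Compound 3 `Cc1cc(C(=O)O)nn1Cc1cc(Br)ccc1OCc1ccccc1Cl` gives 3.16 nM in this assay.

Among these three, compound 1 holds the highest number: compound 3 lies nearest to it, while compound 2 lies furthest away. Compound 4 `Cc1cc(C(=O)O)nn1Cc1cc(Br)ccc1OCc1ccc(C(F)(F)F)cc1` differs from compound 1 by trifluoromethyl in place of hydrogen on an aromatic carbon. Among the compounds with values here, three measured steps bear on this change. Adding a single chloro to the benzyl ring of compound 1 gave a 2.0-fold lower number from compound 1 to compound 3 (0.31 log units; beyond the scatter), a modest step. Going to the 2,4-dichlorophenyl gave a 49-fold lower number from compound 1 to compound 2 (1.69 log units; beyond the scatter), a large step, and stripping one chloro back off that ring gave a 24-fold higher number from compound 2 to compound 3 (1.38 log units; beyond the scatter), so most of the gain in compound 2 rests on substitution at the position that compound 4 now carries its trifluoromethyl. A large step downward in this assay is therefore expected for compound 4, estimated as an 11-fold lower number from compound 1 to compound 4 (1.03 log units; beyond the scatter). Compound 4 is expected to come in near 0.6 nM, with a range from 0.1 nM to 3.5 nM.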

Compound 4, half-maximal inhibitory concentration: 35.5 nM
Compound 4: the middle estimate sits 59-fold (1.77 log units) below what was measured, and the stated range ends below it.
By their numbers in this assay, from the lowest: compound 2; then compound 3; then compound 1; then compound 4.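

In this assay, trifluoromethyl on this aromatic carbon, para to a large group, went the opposite way from the earlier additions to compound 1, giving a 5.5-fold higher number from compound 1 to compound 4 (0.74 log units; beyond the scatter). A group at this place therefore does not lower the number of itself: the gain seen with chloro on the doubly substituted ring of compound 2 does not carry over to trifluoromethyl on an otherwise unsubstituted ring. Nothing measured here accounts for this rise.

The compounds shown leave open whether the identity of the group or the absence of the second chloro decides the outcome; compound 4 differs from compound 2 in both. A lone chloro, a methyl or a methoxy at this place on compound 1, or trifluoromethyl added to compound 3, would separate the two.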